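From Ethoxy to Trifluoromethoxy on a Shared Core

A few compounds are considered here, and "the series" means these few. Any claim that something is new, unique, unknown or untested is made for them only; others in the source may bear on it.

In a functional assay on HT-29 cells (Homo sapiens) for inhibition, read by MTT assay, with a stated time of 72 h (a higher number here means a weaker inhibitor, a lower number a stronger inhibitor), compound 1 `C=C(Br)C(=O)Nc1cccc(/C=C/C(=O)Nc2ccc(Cl)cc2)c1` gives 7900 nM while compound 2 `C=C(Br)C(=O)Nc1cccc(/C=C/C(=O)Nc2ccc(OCC)cc2)c1` gives 3400 nM as the lower of the two numbers, which makes it the stronger inhibitor of the pair. Among the measured compounds shown here, the one measured step, a 2.3-fold lower number from compound 1 to compound 2 (0.37 log units; beyond the scatter) with ethoxy in place of chloro, is modest but beyond the scatter. Compound 3 `C=C(Br)C(=O)Nc1cccc(/C=C/C(=O)Nc2ccc(OC(F)(F)F)cc2)c1` alters that same ethoxy group, and the change reads trifluoromethyl in place of ethyl on an oxygen on an aromatic ring with trifluoromethyl in place of ethyl on an oxygen on an aromatic ring. For the measured compounds named here, only that one step bears on this change, so it is a thin guide. The expected move is a 1.8-fold higher number from compound 2 to compound 3 (0.25 log units; within the scatter) and is estimated to be small, toward a higher number, and no larger than the measured step. In this assay the estimate for compound 3 is 6000 nM with an expected range from 2500 nM to 14000 nM as its lower and upper ends.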

Compound 3, half-maximal inhibitory concentration: 61200 nM
Compound 3: middle estimate off by 10-fold (1.01 log units), on the low side; the whole stated range lies below it.
By their numbers in this assay, from the lowest: compound 2; then compound 1; then compound 3.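

In this assay, this place on the aromatic ring proves far from indifferent to what sits on the oxygen: an 18-fold higher number from compound 2 to compound 3 (1.26 log units; beyond the scatter) is a large step, even though the oxygen stays and only ethyl gives way to trifluoromethyl. Compound 3 also falls behind the chloro compound, with a 7.7-fold higher number from compound 1 to compound 3 (0.89 log units; beyond the scatter), so among these three compounds an oxygen at this place does not by itself bring a lower number. Nothing measured here gives a reason for the size of this step.

Still open, as far as these compounds go, is how other groups at this place would read on the shared core, such as methoxy, a longer propoxy chain or an amine. From the compounds shown here alone, all three compounds share that core, so it also remains unknown whether the same order of ethoxy, chloro and trifluoromethoxy would hold on a different one.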